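The compounds below may be only part of what the source reports. "The series", "measured", "known", "first", "only" and "open" are said of these compounds alone.

Within the data shown here, in a functional assay on A549 cells (Homo sapiens) for antiproliferative activity, read by MTT assay, with a stated time of 48 h (on this read-out lower numbers stand for stronger inhibition and higher numbers for weaker inhibition), compound 1 `O=[N+]([O-])c1cccc(-c2nn(-c3ccccc3)cc2C(Nc2nc3ccccc3s2)c2c(O)ccc3ccccc23)c1` gives 32000 nM and compound 2 `Cc1ccc(-c2nn(-c3ccccc3)cc2C(Nc2nc3cc(C)c(C)cc3s2)c2c(O)ccc3ccccc23)cc1` gives 31200 nM so the two numbers lie within the usual scatter of each other, and compound 1 stands level with the only other measurement available. Compound 3 `Cc1ccc(-c2nn(-c3ccccc3)cc2C(Nc2nc3ccccc3s2)c2c(O)ccc3ccccc23)cc1` differs from compound 1 in one place, with 4-methylphenyl in place of 3-nitrophenyl on an aromatic carbon. Among the measured compounds shown here, no measured pair shows this change alone, so the expectation in this assay is no step beyond the scatter. The estimated move is small (a 1.3-fold lower number from compound 1 to compound 3 (0.11 log units; within the scatter)). For compound 3 the expected value is 25000 nM within an estimated range (10000 nM to 60000 nM).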

Compound 3, half-maximal inhibitory concentration: 57400 nM
Compound 3: the middle estimate sits 2.3-fold (0.36 log units) below what was measured, within the range that was stated.
By their numbers in this assay, from the lowest: compounds 2, 1 and 3 (each within the scatter of the next).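

Swapping 3-nitrophenyl for 4-methylphenyl on this aromatic carbon gives a 1.8-fold higher number from compound 1 to compound 3 (0.25 log units; within the scatter), so in this assay this change alone does not move the number beyond the scatter, even though the two groups differ in their atoms. Swapping 5,6-dimethyl-1,3-benzothiazol-2-yl for 1,3-benzothiazol-2-yl on the amine nitrogen gives a 1.8-fold higher number from compound 2 to compound 3 (0.26 log units; within the scatter), so that second place shows no step beyond the scatter either. No measurement here offers an explanation for these results. Still open, from the compounds shown here alone, is whether a phenyl ring carrying an amine or a carboxylic acid at this position would move the number beyond the scatter.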